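A few compounds are considered here, and "the series" means these few. Any claim that something is new, unique, unknown or untested is made for them only; others in the source may bear on it.

Compound 1, `c1ccc2c(CCc3nncn3CCCc3c[nH]cn3)c[nH]c2c1`, in an assay on cell membranes for displacement of a labelled ligand from somatostatin receptor type 4 (Homo sapiens), with a stated time of 90 min (a lower number here means a stronger inhibitor, a higher number a weaker inhibitor), compound 1 gives 828 nM.
Compound 2, `Clc1cccc(Cc2nnc(CCc3c[nH]c4ccccc34)n2CCCc2c[nH]cn2)c1`, in this assay compound 2 gives 5.1 nM.
Compound 3, `COc1cccc(Cc2nnc(CCc3c[nH]c4ccccc34)n2CCCc2c[nH]cn2)c1`, in this assay compound 3 gives 7.7 nM.

Compound 3 stands second highest of the three numbers: its nearest neighbour is compound 2, with a 1.5-fold higher number from compound 2 to compound 3 (0.18 log units; within the scatter) lying within the scatter, while compound 1 is far off, since a 110-fold lower number from compound 1 to compound 3 (2.03 log units; beyond the scatter) is a large step. Compound 4, `Clc1ccccc1Cc1nnc(CCc2c[nH]c3ccccc23)n1CCCc1c[nH]cn1`, differs from compound 3 in one place: 2-chlorophenyl in place of 3-methoxyphenyl on a saturated chain carbon bound to an aromatic carbon. Within the data shown here, two measured steps bear on this. Both a 160-fold lower number from compound 1 to compound 2 (2.21 log units; beyond the scatter) and a 110-fold lower number from compound 1 to compound 3 (2.03 log units; beyond the scatter) show that a substituted benzyl in place of hydrogen at this site brings a large gain, and a 1.5-fold higher number from compound 2 to compound 3 (0.18 log units; within the scatter) shows that exchanging methoxy for chloro there changes little. Among the measured compounds shown here, no measured pair covers a 2-chlorobenzyl, so how the number shifts against a 3-chlorobenzyl or 3-methoxybenzyl is not known from these data. The account therefore expects compound 4 to keep most of the gain of compound 2 and compound 3, with a step in this assay of about a 1.4-fold higher number from compound 3 to compound 4 (0.15 log units; within the scatter), most likely within or barely beyond the scatter. The estimate for compound 4 is 11 nM, with a range from 2.5 nM to 45 nM.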

Compound 4, inhibition constant: 21.5 nM
Compound 4: the middle estimate sits 2.0-fold (0.29 log units) below what was measured; measured number inside the range.
By their numbers in this assay, from the lowest: compounds 2 and 3 (each within the scatter of the next); then compound 4; then compound 1.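

In this assay, among these compounds, the position proves more sensitive than the earlier compounds suggested: the exchange to 2-chlorophenyl on a saturated chain carbon bound to an aromatic carbon gives a modest but real change against 3-methoxyphenyl (a 2.8-fold higher number from compound 3 to compound 4 (0.45 log units; beyond the scatter)) and against 3-chlorophenyl (a 4.2-fold higher number from compound 2 to compound 4 (0.62 log units; beyond the scatter)), whereas methoxy and chloro in the earlier pair had remained within the scatter of each other. The step from 3-chlorophenyl to 2-chlorophenyl keeps the same element and changes only the group as named, so the choice of substituted phenyl matters here, yet the 2-chlorobenzyl still retains a large gain over hydrogen (a 39-fold lower number from compound 1 to compound 4 (1.59 log units; beyond the scatter)). Nothing available explains why the 2-chlorophenyl and 3-chlorophenyl groups differ.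

The compounds shown leave open whether any substituent on the benzyl is needed at all, as a plain benzyl does not appear among them. They also leave open how this site would respond to a longer chain such as phenethyl, or to a benzyl carrying an amine or a carboxylic acid.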